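The source may hold more compounds than are shown below. What is called first, only, known or untested is meant among the compounds shown, and "the series" means these compounds.

Compound 3 `COC(=O)Nc1c(C)nc2c(OCc3ccccc3)cccn12` carries a methoxy group on its carbonyl carbon and, in a functional assay on the whole organism with Rattus norvegicus as the target, at a dose of 40 mg/kg by the intraperitoneal route (a higher number here means more inhibition at the dose given (going by the name of the read-out), a lower number less inhibition), compound 3 gives 0%, the lowest of the three numbers here. Compound 1 `Cc1nc2c(OCc3ccccc3)cccn2c1NC=O`, with hydrogen on that carbon, gives 49%, and compound 2 `CC(=O)Nc1c(C)nc2c(OCc3ccccc3)cccn12`, with methyl there, gives 93%; the steps of a number 49 percentage points lower from compound 1 to compound 3 (beyond the scatter) and a number 93 percentage points lower from compound 2 to compound 3 (beyond the scatter) are both large. Compound 4 `Cc1nc2c(OCc3ccccc3)cccn2c1NC(=O)OCc1ccccc1` differs from compound 3 by phenyl in place of hydrogen on a saturated chain carbon bound to an oxygen next to a carbonyl group. Within the data shown here, no measured step replaces hydrogen with phenyl at this place, so the only guidance is that the methoxy-bearing compound 3 sits at the bottom. Compound 4 is therefore expected to stay low, with the estimated step of a number 15 percentage points higher from compound 3 to compound 4 (beyond the scatter) small. Compound 4 is estimated at 15%, within a range of 0% to 55%.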

Compound 4, a percentage reported as inhibition, in the whole organism at one dose (the size of the read-out at that dose, not a potency): 8%
Compound 4: the middle estimate sits 7 percentage points above what was measured; measured number inside the range.
By their numbers in this assay, from the lowest: compounds 3 and 4 (each within the scatter of the next); then compound 1; then compound 2.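

In this assay, replacing hydrogen with phenyl at this place, which turns methoxy into benzyloxy, gives a number 8 percentage points higher from compound 3 to compound 4 (within the scatter), so the larger group does not bring the number back up. Benzyloxy stays far from the smaller groups on the carbonyl carbon, with a number 85 percentage points lower from compound 2 to compound 4 (beyond the scatter) and a number 41 percentage points lower from compound 1 to compound 4 (beyond the scatter), so both oxygen-linked groups here give low numbers, while hydrogen and methyl give higher ones. Nothing available explains this difference. From the compounds shown here alone, it remains open whether an ethyl group or a longer chain on the carbonyl carbon would match methyl, and how an amine there would behave.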